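Swapping the group on the sulfonyl sulfur

The source may hold more compounds than are shown below. What is called first, only, known or untested is meant among the compounds shown, and "the series" means these compounds.

Of the compounds shown here, two have numbers so far in a physicochemical assay for solubility, in phosphate buffer, with a stated time of 24 h, at pH 7.4, tested at 100 uM (a lower number here means a less soluble compound, a higher number a more soluble compound), and they sit close together. Among the measured compounds shown here, compound 1 `O=C(NCc1ccc(S(=O)(=O)c2ccccc2)cc1)N1CCc2ccncc2C1` gives 115000 nM and compound 2 `CC(C)n1cc(S(=O)(=O)c2ccc(CNC(=O)N3Cc4ccncc4C3)cc2)cn1` gives 192000 nM and these two values lie within the scatter of each other, so compound 2 stands level with the only other measured compound. Compound 3 `O=C(NCc1ccc(S(=O)(=O)C2CCN(C3COC3)CC2)cc1)N1Cc2ccncc2C1` follows from compound 2 by one change, 1-(oxetan-3-yl)piperidin-4-yl in place of 1-isopropyl-1H-pyrazol-4-yl on a sulfonyl sulfur, counted as 1-(oxetan-3-yl)piperidin-4-yl in place of 1-isopropyl-1H-pyrazol-4-yl on a sulfonyl sulfur in full. For the measured compounds named here, no measured pair differs in one place only, so the series holds no direct precedent for this change. The a 1.1-fold lower number from compound 2 to compound 3 (0.05 log units; within the scatter) that is expected here stays within the scatter, with no direction favoured. In this assay compound 3 is estimated at 170000 nM with a range from 80000 nM to 350000 nM as the working expectation.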

Compound 3, solubility: 121000 nM
Beside the measured number, compound 3's estimate is 1.4-fold (0.15 log units) above it; the measured number falls inside the stated range.
By their numbers in this assay, from the lowest: compounds 1, 3 and 2 (each within the scatter of the next).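

In this assay, the group on a sulfonyl sulfur whose other neighbours are aromatic carbon now has its first direct step: 1-(oxetan-3-yl)piperidin-4-yl in place of 1-isopropyl-1H-pyrazol-4-yl gives a 1.6-fold lower number from compound 2 to compound 3 (0.20 log units; within the scatter), so this read-out does not separate the two groups. The exchange replaces one five-membered aromatic ring with a four-membered and a six-membered non-aromatic ring, and the hydrogen-bond donor and acceptor counts stay the same, so the step does not test a change in those counts. No measurement available here accounts for the size of this step.

From the compounds shown here alone, whether any group on this sulfonyl sulfur can move the number beyond the scatter remains open, for example a carboxylic acid or a primary amine in place of 1-(oxetan-3-yl)piperidin-4-yl. Also open, going by these compounds, is whether this step would carry over to the core of compound 1.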